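A Smaller Amide Replaces a Ring on the Shared Core

A few compounds are considered here, and "the series" means these few. Any claim that something is new, unique, unknown or untested is made for them only; others in the source may bear on it.

Of the compounds shown here, three sharing one core have been measured in a functional assay for inhibition, with Homo sapiens as the target; on this read-out higher numbers stand for weaker inhibition and lower numbers for stronger inhibition. Compound 1 `Cc1cccc(Nc2nccc(-c3cc(C)oc3C)n2)c1` gives 28500 nM. Compound 2 `COc1cccc(Nc2nccc(-c3ccc(C)o3)n2)c1` gives 1500 nM. Compound 3 `CC1CCN(c2ccc(Nc3nccc(-c4cccnc4)n3)cc2)CC1` gives 500 nM, the lowest of the three and thus the strongest inhibitor in this set; its nearest neighbour is compound 2, whose number is beyond the usual scatter, and compound 1 lies much further away.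

Compound 4 `CC(=O)Nc1ccc(Nc2nccc(-c3cccnc3)n2)cc1` has not yet been measured in this assay. It differs from compound 3 in one place: acetamido in place of 4-methylpiperidin-1-yl on an aromatic carbon. The group that leaves is a ring with a single hydrogen-bond acceptor; the group that enters is acetamido, which has no ring but brings one hydrogen-bond donor and one hydrogen-bond acceptor.

Among the measured compounds shown here, no measured pair in this set shows what such a change does, so there is no step to lean on. The expectation is a modest weakening from compound 3 to compound 4 in this assay, a 3.0-fold higher number from compound 3 to compound 4 (0.48 log units; beyond the scatter), since the two groups differ so much in size and shape, with a real chance of no change beyond the scatter. Compound 4 is therefore expected to give about 1500 nM, within a range of 400 nM to 6000 nM.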

Compound 4, half-maximal inhibitory concentration: 3600 nM
The estimate for compound 4 lay 2.4-fold (0.38 log units) below the measured number; the range from low to high includes it.
By their numbers in this assay, from the lowest: compound 3; then compound 2; then compound 4; then compound 1.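

Among the compounds shown here, this is the first pair in the set that differs in only one place, so it gives the first direct reading of this position, an aromatic carbon para to a large group. In this assay, putting acetamido in place of 4-methylpiperidin-1-yl, with everything else in the molecule unchanged, gives a clear weakening (a 7.2-fold higher number from compound 3 to compound 4 (0.86 log units; beyond the scatter)), so the group held here does affect the read-out, and the smaller, ring-free group with a hydrogen-bond donor is the less favourable of these two, although compound 4 still gives a measurable number (3600 nM). Nothing measured alongside these numbers explains why the two groups differ.

The compounds shown leave open which part of the change matters most: the loss of the ring, the smaller size of the group or the arrival of the amide hydrogen. A dimethylamino group or a longer amide chain such as propanamido, placed at this same position on the core of compound 3, would help to tell these apart.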